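Trifluoromethyl for Fluoro on a Quinoline-free Shared Core

A few compounds are considered here, and "the series" means these few. Any claim that something is new, unique, unknown or untested is made for them only; others in the source may bear on it.

Measured so far:
Compound 1 `Cc1c(C(=O)Nc2c(F)cc(-c3cccc(F)c3)cc2F)nc2ccc(C(F)(F)F)cc2c1O` gives 1.35% in a functional assay on Hep 3B2 cells (Homo sapiens) for antiproliferative activity, read by MTT assay, with a stated time of 24 h, tested at 0.05 ug/mL; a higher number here means a stronger effect of the compound at the concentration tested, a lower number a weaker effect.
Compound 2 `Cc1c(C(=O)Nc2c(F)cc(-c3cccc(F)c3)cc2F)nc2ccc(F)cc2c1C(=O)O` gives 0.05% in this assay.

On these two numbers, compound 2 and compound 1 lie within the usual scatter of each other, and neither shows an effect that stands apart from no effect at all at this concentration.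

Compound 3 `Cc1c(C(=O)Nc2c(F)cc(-c3cccc(F)c3)cc2F)nc2ccc(C(F)(F)F)cc2c1C(=O)O` is the next compound to be measured in this assay. It differs from compound 2 in one place: trifluoromethyl in place of fluoro on an aromatic carbon. Within the data shown here, no step between measured compounds is available for this change, so its size cannot be read from earlier pairs.

Given that compound 1, which already carries the trifluoromethyl, shows 1.35%, and compound 2 shows 0.05%, the step of a number 1.5 percentage points higher from compound 2 to compound 3 (within the scatter) is expected to stay within the scatter, with no direction that can be trusted. Compound 3 is therefore estimated at 1.5%, with a range from 0% to 9%.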

Compound 3, a percentage reported as inhibition, at one concentration (the size of the read-out at that concentration, not a potency): 1.68%
Beside the measured number, compound 3's estimate is 0.2 percentage points below it; low and high end bracket the measured number.
By their numbers in this assay, from the lowest: compounds 2, 1 and 3 (each within the scatter of the next).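

Putting trifluoromethyl in place of fluoro on this aromatic carbon gives a number 1.6 percentage points higher from compound 2 to compound 3 (within the scatter) in this assay and so leaves no mark that can be told from the scatter at this concentration. Compound 3 also allows a second comparison, carboxy in place of hydroxy on an aromatic carbon, which gives a number 0.3 percentage points higher from compound 1 to compound 3 (within the scatter) and is equally unreadable. Neither single change separates its pair, and none of the three compounds stands apart from no effect at all.

From the compounds shown here alone, what an amine or a longer chain on this aromatic carbon would do remains open, as does whether either change would matter on a compound with a clear effect in this assay. Nothing at hand beyond these numbers speaks to why they lie so close together.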